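This account rests on a few compounds, and the source may have more. Where it says the series, first, only, none or still open, it means among the compounds named here.

Going by the values given here, in a functional assay on Huh-7 cells (Homo sapiens) for antiproliferative activity, read by sulforhodamine B assay, with a stated time of 72 h (on this read-out higher numbers stand for weaker inhibition and lower numbers for stronger inhibition), compound 3 `N#Cc1cccc(COc2ccc(-c3cc(CN4CCN(c5ccc(C(F)(F)F)cc5)CC4)no3)cc2)c1` gives 2200 nM, the highest of the three numbers so far. The nearest is compound 2 `COc1cc(COc2ccc(-c3cc(CN4CCN(Cc5ccc(C(F)(F)F)cc5)CC4)no3)cc2)cc(OC)c1` with 1500 nM, a gap within the scatter, while compound 1 `FC(F)(F)c1ccc(CN2CCN(Cc3cc(-c4ccc(OCc5cccc(Cl)c5)cc4)on3)CC2)cc1` with 200 nM lies far beyond it. Among the compounds with values here, the one single-point step measured, a 7.5-fold higher number from compound 1 to compound 2 (0.88 log units; beyond the scatter), concerns the group on the benzyl ether and not the amine nitrogen in the ring.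

Compound 4 `N#Cc1cccc(COc2ccc(-c3cc(CN4CCN(C(=O)C5CC5)CC4)no3)cc2)c1` differs from compound 3 at that ring nitrogen: cyclopropylcarbonyl in place of 4-(trifluoromethyl)phenyl on an amine nitrogen in a ring. Within the data shown here, no measured step bears on this change, since compounds 1 and 2 carry a benzyl group there and compound 3 an aryl group, and nothing shows how a cyclopropylcarbonyl behaves at this position. Among the measured compounds shown here, with no precedent, a step of moderate size in either direction is possible; a weakening is expected as likely as a gain, so the estimate leans only slightly toward a higher number in this assay, with a wide range. The expected step of a 1.4-fold higher number from compound 3 to compound 4 (0.13 log units; within the scatter) would leave compound 4 near compound 3. Compound 4 is therefore estimated at 3000 nM, within 800 nM to 12000 nM.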

Compound 4, half-maximal inhibitory concentration: 2800 nM
The estimate for compound 4 lay 1.1-fold (0.03 log units) above the measured number; the range from low to high includes it.
By their numbers in this assay, from the lowest: compound 1; then compounds 2, 3 and 4 (each within the scatter of the next).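

In this assay, the exchange on the amine nitrogen in the ring gives a 1.3-fold higher number from compound 3 to compound 4 (0.10 log units; within the scatter), so the read-out does not separate the cyclopropylcarbonyl from the 4-(trifluoromethyl)phenyl at this position. Going by these compounds alone, the exchange removes a six-membered aromatic ring and the fluorine atoms and brings in a three-membered ring and a hydrogen-bond acceptor, yet the step stays within the scatter, something the earlier compounds, with no pair differing at this nitrogen, could not show. Nothing given here explains this result.

As far as these compounds go, it remains open how a sulfonyl group, an acetyl group or a longer acyl chain on this nitrogen would read. From the compounds shown here alone, it is also open whether the same exchange would stay within the scatter with the 3-chlorophenyl of compound 1 on the benzyl ether.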